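Methyl removal on the pyridyl ring: two matched pairs

A few compounds are considered here, and "the series" means these few. Any claim that something is new, unique, unknown or untested is made for them only; others in the source may bear on it.

Three amidrazone thiosemicarbazides have been run in a functional assay on A-431 cells (Homo sapiens) for cytotoxicity, read by MTT assay, with a stated time of 72 h, tested at 30 uM; a lower number here means less inhibition of growth, a higher number more inhibition of growth at the concentration tested. Compound 2 `N/C(=N\NC(=S)N1CCCCC1)c1ccccn1` gives 79.7%, compound 3 `Cc1cccc(/C(N)=N/NC(=S)N2CCCCC2)n1` gives 65.2%, and compound 1 `Cc1ccnc(/C(N)=N/NC(=S)N2CCN(c3ccccn3)CC2)c1` gives 65.7%. Compound 2 and compound 3 differ in one place, (hydrogen in place of methyl on an aromatic carbon), and the step is a number 14.5 percentage points higher from compound 3 to compound 2 (beyond the scatter). Compound 1 and compound 3 carry different cores; that difference is not broken down here.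

Compound 4 `N/C(=N\NC(=S)N1CCN(c2ccccn2)CC1)c1ccccn1` is not yet measured. It differs from compound 1 by hydrogen in place of methyl on an aromatic carbon, the same kind of change as from compound 3 to compound 2, though not the same: in the measured pair the carbon is next to the ring nitrogen, in the new pair it is opposite the ring nitrogen, both meta to a large group. Among the compounds with values here, with only one measured example of this change, the expectation rests on that single step; the step expected from compound 1 is a number 11.3 percentage points higher from compound 1 to compound 4 (beyond the scatter). For compound 4 the estimate in this assay is 77%, with a range from 66% to 88%.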

Compound 4, percent growth inhibition at one concentration: 74.9%
Compound 4: the middle estimate sits 2.1 percentage points above what was measured, and the stated range covers the measured number.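

In this assay, the change from 4-methylpyridin-2-yl to pyridin-2-yl on the core of compound 1 gives a number 9.2 percentage points higher from compound 1 to compound 4 (within the scatter). Taken with the earlier pair, the data show that the size of this change cannot be told apart between the two cores: the same change on two cores in this assay, a number 14.5 percentage points higher (beyond the scatter) from compound 3 to compound 2 and a number 9.2 percentage points higher (within the scatter) from compound 1 to compound 4, 5.3 percentage points apart, within the scatter of two such steps This does not establish a real gain on the core of compound 1, where the step alone stays within the scatter, and it does not separate an effect of core from one of ring position, as the methyl leaves a different ring carbon in each pair.

The compounds shown leave open whether a group other than methyl on these ring carbons, such as an ethyl, a methoxy or an amine, would give a step of similar size on either core. Also open, on these data alone, is whether the two steps would keep the same size at other concentrations or in other cell lines, as each pair is read here at a single concentration in one cell line.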